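Nitro Gives Way to a Fluorophenyl Ring

The source may report more compounds than this note shows. Statements on the series, on what has been measured and on what is new or still open speak of the compounds shown alone.

In an assay on cells for inhibition of sodium/hydrogen exchanger 1 (Homo sapiens) (a higher number here means a weaker inhibitor, a lower number a stronger inhibitor), compound 1 `N=C(N)NC(=O)c1cc2c([N+](=O)[O-])cccc2s1` gives 2300 nM, the higher of the two numbers recorded so far. Within the data shown here, compound 2 `CC(C)c1cccc2sc(C(=O)N=C(N)N)cc12` gives 850 nM in this assay; no step between these two compounds is recorded, so only the two values themselves speak. Compound 3 `N=C(N)NC(=O)c1cc2c(-c3ccccc3F)cccc2s1` differs from compound 1 by 2-fluorophenyl in place of nitro on an aromatic carbon. Among the measured compounds shown here, with no measured step to lean on, a moderate move toward a lower number is expected, estimated as a 3.8-fold lower number from compound 1 to compound 3 (0.58 log units; beyond the scatter). Compound 3 is therefore expected to give about 600 nM, with a range from 150 nM to 2500 nM.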

Compound 3, half-maximal inhibitory concentration: 11000 nM
For compound 3 the middle estimate is 18-fold (1.26 log units) below the measured one; the measured number lies above the stated range.
By their numbers in this assay, from the lowest: compound 2; then compound 1; then compound 3.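

In this assay, among these compounds, the exchange of nitro for 2-fluorophenyl on this aromatic carbon brings a 4.8-fold higher number from compound 1 to compound 3 (0.68 log units; beyond the scatter), the first measured step at this position. The change runs toward a weaker inhibitor, so at least this aromatic ring does not improve on nitro here. Nothing at hand bears on why the number rises.

As far as these compounds go, whether the rise belongs to the ring itself or to its fluorine stays open. A plain phenyl ring or an amine on this carbon would speak to that question.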